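Cytotoxicity notes: piperidine to phenylpiperazine on compound 2

A few compounds are considered here, and "the series" means these few. Any claim that something is new, unique, unknown or untested is made for them only; others in the source may bear on it.

Compound 1 `O=C(CN1CCCCC1)Nc1ccc(-c2nc3cc(C(F)(F)F)ccc3[nH]2)cc1` gives 31000 nM in an ADME assay on Vero cells (Chlorocebus sabaeus) for cytotoxicity; a lower number here means that less compound is tolerated, a higher number that more compound is tolerated.
Compound 2 `Cn1c(-c2ccc(NC(=O)CN3CCCCC3)cc2)nc2cc(C(F)(F)F)ccc21` gives > 100000 nM in this assay, which is a limit of the assay.
Compound 3 `Cn1c(-c2ccc([N+](=O)[O-])cc2)nc2cc(C(F)(F)F)ccc21` gives > 100000 nM in this assay, again a limit.

Compound 2 stands at the top of the shown numbers, though only as a limit and not as a measured value. The step of an at least 3.2-fold higher number from compound 1 to compound 2 (0.50 log units; beyond the scatter) puts compound 2 clearly past compound 1. The step that the two limits leave unreadable from compound 2 to compound 3 cannot be sized because of the limit of > 100000 nM in this assay, at which 2 of the 3 values shown sit.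

Compound 4 `Cn1c(-c2ccc(NC(=O)CN3CCN(c4ccccc4)CC3)cc2)nc2cc(C(F)(F)F)ccc21` is not yet measured. It differs from compound 2 by 4-phenylpiperazin-1-yl in place of piperidin-1-yl on a saturated chain carbon bound to a carbonyl carbon. For the measured compounds named here, neither measured step touches the chain attached to the carbonyl carbon, so no measured step bears directly on this change, and the starting point is itself a limit. The expected step is therefore an at least 1.4-fold lower number from compound 2 to compound 4 (0.15 log units; that floor lies within the scatter), a value that could equally sit at the limit again. Compound 4 is expected to give 70000 nM in this assay, within 20000 nM to 250000 nM.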

Compound 4, half-maximal cytotoxic concentration: 30000 nM
Beside the measured number, compound 4's estimate is 2.3-fold (0.37 log units) above it; low and high end bracket the measured number.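

Changing the chain attached to the carbonyl carbon matters in this assay: 4-phenylpiperazin-1-yl in place of piperidin-1-yl gives an at least 3.3-fold lower number from compound 2 to compound 4 (0.52 log units; beyond the scatter). With the methyl on the aromatic nitrogen kept, compound 4 gives a measured number and not a limit, so the shared core does not by itself hold a compound at the limit. The size of this step remains a floor, since the value for compound 2 is a limit: the limit of > 100000 nM in this assay, at which 2 of the 4 values shown sit.

On these data alone, it remains open whether the drop follows the added phenyl ring or the second ring nitrogen; a 4-methylpiperazin-1-yl or morpholin-4-yl group on this chain carbon would separate the two. Also open, as far as these compounds go, is whether the same exchange has a similar effect with hydrogen in place of methyl on the aromatic nitrogen, as in compound 1.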